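Dropping a Chloro Group from a Weakly Active Amide

A few compounds are considered here, and "the series" means these few. Any claim that something is new, unique, unknown or untested is made for them only; others in the source may bear on it.

Compound 2 `O=C(Nc1ccc(Cl)c(-c2nnc3c(Cl)cccn23)c1)c1cccc(Cl)c1`: 52700 nM
Compound 1 `O=C(Nc1ccc(Cl)c(-c2nnc3c(Cl)cccn23)c1)c1ccc(C(F)(F)F)cc1F`: limit only

Within the data shown here, in a functional assay on A549 cells (Homo sapiens) for antiproliferative activity, read by MTT assay, with a stated time of 72 h (a lower number here means a stronger inhibitor, a higher number a weaker inhibitor), compound 2 gives 52700 nM, the only measured number here. For compound 1 the result > 100000 nM is a limit of the assay, not a number, namely (the limit of > 100000 nM in this assay, at which 1 of the 2 values shown sits). Compound 3 `O=C(Nc1ccc(Cl)c(-c2nnc3c(Cl)cccn23)c1)c1ccccc1` differs from compound 2 by hydrogen in place of chloro on an aromatic carbon. Among the measured compounds shown here, no measured pair shows this change, so the expected step is uncertain; a modest weakening, barely beyond the scatter, is expected as a 1.6-fold higher number from compound 2 to compound 3 (0.21 log units; within the scatter). Compound 3 is therefore estimated at 85000 nM, within 30000 nM to 250000 nM.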

Compound 3, half-maximal inhibitory concentration: 76900 nM
Beside the measured number, compound 3's estimate is 1.1-fold (0.04 log units) above it, within the range that was stated.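

Replacing chloro with hydrogen at this position of the ring gives, in this assay, a 1.5-fold higher number from compound 2 to compound 3 (0.16 log units; within the scatter). Among these compounds, this is the first single change that can be read here, and it shows that 3-chlorophenyl and phenyl cannot be told apart in this assay, with both compounds only weakly active. Nothing measured here bears on why the two compounds read alike. Still open, going by these compounds, is whether a different group at this position, such as a methoxy group or an amine, would move the number beyond the scatter.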